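Fused-ring substituent swap: efficacy notes before compound 4

A few compounds are considered here, and "the series" means these few. Any claim that something is new, unique, unknown or untested is made for them only; others in the source may bear on it.

Measured compounds:
Compound 1, `O=C(O)CCc1ccc(-c2ccc3cnn(-c4ccccn4)c3c2)cc1`: in a functional assay on cells for agonist activity at Free fatty acid receptor 1 (Mus musculus), read by FLIPR and calcium flux, with a stated time of 5 min (a higher number here means a larger maximal response, a lower number a smaller maximal response), compound 1 gives 106%.
Compound 2, `Cc1cc(-c2ccc(CCC(=O)O)cc2)cc2c1cnn2-c1ccccn1`: in this assay compound 2 gives 82%.
Compound 3, `O=C(O)CCc1ccc(-c2cc(F)c3cnn(-c4ccccn4)c3c2)cc1`: in this assay compound 3 gives 126%.

Compound 3 stands highest of the three in this assay; both steps leading to it, a number 20 percentage points higher from compound 1 to compound 3 (beyond the scatter) and a number 44 percentage points higher from compound 2 to compound 3 (beyond the scatter), lie beyond the scatter. Compound 4, `N#Cc1cc(-c2ccc(CCC(=O)O)cc2)cc2c1cnn2-c1ccccn1`, is not yet measured. Its change from compound 3: cyano in place of fluoro on an aromatic carbon.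

The measured steps at this same aromatic carbon bear on the question: a number 20 percentage points higher from compound 1 to compound 3 (beyond the scatter) was a modest rise, a number 24 percentage points lower from compound 1 to compound 2 (beyond the scatter) a modest fall, and a number 44 percentage points higher from compound 2 to compound 3 (beyond the scatter) a large rise. Cyano occurs in none of the measured compounds, and the two substituents already tried at this place moved the maximal response in opposite directions, so the direction for cyano is open. The working expectation is a modest downward step, a number 21 percentage points lower from compound 3 to compound 4 (beyond the scatter), back toward the level of compound 1. Compound 4 is therefore estimated to give 105% in this assay, with a range from 70% to 140%.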

Compound 4, largest response reached (reported as efficacy), in percent of the reference or control that the assay uses in the Free fatty acid receptor 1 assay: 113%
Compound 4: middle estimate off by 8 percentage points, on the low side; the measured number falls inside the stated range.
By their numbers in the Free fatty acid receptor 1 assay, from the lowest: compound 2; then compounds 1 and 4 (each within the scatter of the next); then compound 3.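

In the Free fatty acid receptor 1 assay, cyano at this aromatic carbon gives no change that can be read against hydrogen, a number 7 percentage points higher from compound 1 to compound 4 (within the scatter), yet it clearly exceeds methyl, a number 31 percentage points higher from compound 2 to compound 4 (beyond the scatter), and falls short of fluoro, a number 13 percentage points lower from compound 3 to compound 4 (beyond the scatter). The position therefore accepts a group carrying a triple bond and a hydrogen-bond acceptor without loss of maximal response relative to hydrogen, and among the four compounds only the methyl of compound 2 sits under that level. In a physicochemical assay for lipophilicity, using the shake flask method, measured as octanol-water partition, with a stated time of 30 min, at pH 7.4 (on this read-out higher numbers stand for higher lipophilicity and lower numbers for lower lipophilicity), compound 3 gives 2.8 and compound 4 gives 2.2, so cyano in place of fluoro lowers lipophilicity at a modest cost in maximal response: the measured distribution coefficient of compound 3, 2.8, and of compound 4, 2.2, a number 0.60 log units lower (beyond the scatter)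

As far as these compounds go, whether an amine or a methoxy group at this aromatic carbon would hold the maximal response in the Free fatty acid receptor 1 assay remains open. Two compounds also cannot settle whether maximal response follows lipophilicity across this position.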